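The source may report more compounds than this note shows. Statements on the series, on what has been measured and on what is new or still open speak of the compounds shown alone.

The compounds here share one core, seen in compound 1 `O=C(c1cccc(Cl)c1)N1CCC(NS(=O)(=O)c2cc(S(=O)(=O)c3ccccc3)ccc2C(F)(F)F)CC1` and compound 2 `CN(C)c1ccc(C(=O)N2CCC(NS(=O)(=O)c3cc(S(=O)(=O)c4ccccc4)ccc3C(F)(F)F)CC2)cc1`, and differ only in the group on the ring nitrogen. In an assay on U2OS cells for inhibition of secreted frizzled-related protein 1 (Homo sapiens), read by a luciferase reporter, with a stated time of 18 h (a lower number here means that less compound is needed, a higher number that more compound is needed for the effect), compound 1 gives 870 nM, while compound 2 gives 190 nM, the lowest of the two numbers measured. Within the data shown here, the single measured step, a 4.6-fold lower number from compound 1 to compound 2 (0.66 log units; beyond the scatter), shows that the group on this nitrogen can shift the number beyond the scatter.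

Compound 3 `O=S(=O)(NC1CCN(S(=O)(=O)c2ccccc2)CC1)c1cc(S(=O)(=O)c2ccccc2)ccc1C(F)(F)F` has not been measured. It differs from compound 2 by phenylsulfonyl in place of (4-(dimethylamino)phenyl)carbonyl on an amine nitrogen in a ring. Among the measured compounds shown here, no measured step covers an exchange of a carbonyl for a sulfonyl at this nitrogen, so the only guide is that the step from compound 1 to compound 2 moved the number with a change of the aryl group here. Because compound 2 gained over compound 1 by a 4.6-fold lower number from compound 1 to compound 2 (0.66 log units; beyond the scatter) with the dimethylamino group present, removing it is expected to cost some of that gain, so the step of a 3.2-fold higher number from compound 2 to compound 3 (0.50 log units; beyond the scatter) is expected, with wide uncertainty. Compound 3 is therefore estimated at 600 nM, within a range from 150 nM to 2500 nM.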

Compound 3, half-maximal effective concentration: 210 nM
For compound 3 the middle estimate is 2.9-fold (0.46 log units) above the measured one, and the stated range covers the measured number.
By their numbers in this assay, from the lowest: compounds 2 and 3 (each within the scatter of the next); then compound 1.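

In this assay, phenylsulfonyl in place of (4-(dimethylamino)phenyl)carbonyl on the ring nitrogen gives a 1.1-fold higher number from compound 2 to compound 3 (0.04 log units; within the scatter), so these two compounds cannot be told apart. The other new step, a 4.1-fold lower number from compound 1 to compound 3 (0.62 log units; beyond the scatter), shows that a group with neither a dimethylamino group nor a carbonyl can also give a number clearly lower than that of the 3-chlorophenyl amide. Nothing available explains this result.

From the compounds shown here alone, the link and the substituent on the aryl ring change together here, so their separate contributions remain unknown; phenylcarbonyl and (4-(dimethylamino)phenyl)sulfonyl would pull them apart. Going by these compounds, it also remains open whether the aromatic ring on the sulfonyl matters, which a methylsulfonyl group on the same nitrogen would test.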